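From phenyl to 4-methylphenyl on compound 3

This account rests on a few compounds, and the source may have more. Where it says the series, first, only, none or still open, it means among the compounds named here.

Values from a functional assay on MDA-MB-468 cells (Homo sapiens) for antiproliferative activity, read by MTT assay, with a stated time of 72 h (a higher number here means a weaker inhibitor, a lower number a stronger inhibitor), follow
Compound 1 `CCCn1ccnc1-c1cc(OC)c(OC)c(OC)c1` gives > 100000 nM (a limit)
Compound 2 `CCCCCn1ccnc1-c1cc(OC)c(OC)c(OC)c1` gives 57900 nM
Compound 3 `COc1cc(-c2nccn2S(=O)(=O)c2ccccc2)cc(OC)c1OC` gives > 100000 nM (a limit)

In this assay compound 3 stands at the limit of > 100000 nM in this assay, at which 2 of the 3 values shown sit, and that is a limit, not a number. Compound 4 `COc1cc(-c2nccn2S(=O)(=O)c2ccc(C)cc2)cc(OC)c1OC` has methyl in place of hydrogen on an aromatic carbon and this turns phenyl to 4-methylphenyl. Among the measured compounds shown here, the one measured step is an at least 1.7-fold lower number from compound 1 to compound 2 (0.23 log units; that floor lies within the scatter) and it sits on a saturated chain, so it says little about a change on an aromatic carbon. In this assay no step beyond the scatter is therefore expected. The expected step is a number no higher from compound 3 to compound 4 (the limit leaves the size open) and it should be read as a rough estimate. Compound 4 is estimated at 100000 nM with a range from 45000 nM to 200000 nM and may well return only a limit.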

Compound 4, half-maximal inhibitory concentration: > 100000 nM
Compound 4: only a limit was reported (the forecaster's own chance of this, stated with the estimate: 70%); the middle value lies on the limit itself.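

Compound 3 and compound 4 both return only a limit, not a number, so no step can be read between them: the limit of > 100000 nM in this assay, at which 3 of the 4 values shown sit.

The compounds shown leave open whether turning phenyl into 4-methylphenyl changes the activity at all.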